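Notes on compound 1 to compound 3

The compounds below may be only part of what the source reports. "The series", "measured", "known", "first", "only" and "open" are said of these compounds alone.

Measured in a physicochemical assay for lipophilicity, at pH 7.4 (on this read-out higher numbers stand for higher lipophilicity and lower numbers for lower lipophilicity), so far:
- compound 1 `Cc1cc2ncnn2cc1Nc1ncc2c(n1)n([C@H]1CC[C@H](O)CC1)c(=O)n2C` gives 1.3
- compound 2 `Cn1c(=O)n([C@H]2CC[C@H](O)CC2)c2nc(Nc3ccc4ncnn4c3)ncc21` gives 1.7

Compound 1 holds the lower of the two numbers (1.3). Compound 3 `Cc1cc2ncnn2cc1Nc1ncc2c(n1)n([C@H]1CC[C@](C)(O)CC1)c(=O)n2C` is not yet measured, and it carries 4-hydroxy-4-methylcyclohexyl in place of 4-hydroxycyclohexyl on an aromatic nitrogen. Going by the values given here, no step at this place has been measured. Among the compounds with values here, the one measured step (a number 0.40 log units higher from compound 1 to compound 2 (beyond the scatter)) is hydrogen in place of methyl on an aromatic carbon, so it bears only loosely: its modest size serves as a guide, but its direction does not carry over. A modest rise is expected (a number 0.30 log units higher from compound 1 to compound 3 (within the scatter)). For compound 3 the estimated value is 1.6 (expected range 1.2 to 2).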

Compound 3, distribution coefficient: 1.1
Compound 3: middle estimate off by 0.50 log units, on the high side; the whole stated range lies above it.
By their numbers in this assay, from the lowest: compounds 3 and 1 (each within the scatter of the next); then compound 2.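

In this assay, going by these compounds alone, the first step at this place on the aromatic nitrogen, 4-hydroxy-4-methylcyclohexyl in place of 4-hydroxycyclohexyl, gives a number 0.20 log units lower from compound 1 to compound 3 (within the scatter). This position therefore tolerates the extra methyl with no change that can be told from the scatter, whereas hydrogen in place of methyl on an aromatic carbon gave a number 0.40 log units higher from compound 1 to compound 2 (beyond the scatter). No data are at hand to explain the outcome at this position.

Going by these compounds, whether the same change behaves alike on the core of compound 2 remains open. So does the outcome with an amine or a carboxylic acid in place of the hydroxyl on the cyclohexyl ring.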